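Halogen swap on the pendant aryl group of compound 1

The compounds below may be only part of what the source reports. "The series", "measured", "known", "first", "only" and "open" are said of these compounds alone.

Measured so far in a functional assay on the whole organism with Mus musculus as the target, in the maximal electroshock model, with a stated time of 4 h; on this read-out lower numbers stand for an effect already at smaller amounts and higher numbers for an effect only at larger amounts of compound:
compound 1, `SC1=NC(n2nc(-c3ccccc3)nc2-c2ccccc2)=CC(c2ccc(Cl)cc2)N1`: 300 mg/kg
compound 2, `COc1ccc(C2C=C(n3cc(-c4ccccc4)nc3-c3ccccc3)N=C(S)N2)cc1`: 300 mg/kg
compound 3, `CN(C)c1ccc(C2C=C(n3cc(-c4ccccc4)nc3-c3ccccc3)N=C(S)N2)cc1`: 300 mg/kg

Compound 1 sits level with compounds 2 and 3 at the digits shown; the gap to compound 2 and the gap to compound 3 both fall within the scatter, so no order among the three can be read from these numbers. Going by the values given here, the one step that is computed, no change at the digits printed from compound 2 to compound 3 (within the scatter), replaces methoxy with dimethylamino on an aromatic carbon and leaves the read-out where it was.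

Compound 4, `SC1=NC(n2nc(-c3ccccc3)nc2-c2ccccc2)=CC(c2ccc(Br)cc2)N1`, is the next member to be tested. It differs from compound 1 by bromo in place of chloro on an aromatic carbon. Among the compounds with values here, no measured step exchanges one halogen for another, so the only bearing evidence is indirect: every substituent swap on that six-membered aromatic ring of carbon only that has been measured, including the methoxy to dimethylamino step, left the read-out unchanged. On that basis the step of no change at the digits printed from compound 1 to compound 4 (within the scatter) is expected to stay within the scatter, with no direction favoured. Compound 4 is therefore estimated at 300 mg/kg in this assay, with a range from 150 mg/kg to 600 mg/kg.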

Compound 4, minimum effective dose: 300 mg/kg
Compound 4: middle estimate and measured number agree at the digits printed; measured number inside the range.
By their numbers in this assay, from the lowest: compounds 1, 2, 3 and 4 (each within the scatter of the next).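

In this assay, going by these compounds alone, the step of no change at the digits printed from compound 1 to compound 4 (within the scatter) is the first halogen exchange read, and on this read-out it does not separate the 4-chlorophenyl from the 4-bromophenyl group. The earlier step, a swap of methoxy for dimethylamino, was read on a different core, so the result adds a second substituent exchange within the scatter, now on the core of compound 1 and between two groups that each add one heavy atom and no hydrogen-bond donor or acceptor. No measurement is available to explain this result or to connect it to any property of the two halogens.

The compounds shown leave open whether any group at this position can move the read-out away from the shared level, for instance a carboxylic acid, a primary amine, a longer alkyl chain or simply hydrogen in place of the halogen. They also leave open whether the read-out responds to changes elsewhere in the core of compound 1, such as replacing the sulfur substituent with an amine or removing one of the two phenyl groups from the shared core.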